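Enantiomer of a bromophenyl urea in a rice whole-organism assay

The source may report more compounds than this note shows. Statements on the series, on what has been measured and on what is new or still open speak of the compounds shown alone.

Compound 1 `Cc1cccc(NC(=O)N[C@@H](C)c2ccccc2)c1` and compound 2 `C[C@@H](NC(=O)Nc1cccc(Br)c1)c1ccccc1` share a urea linking an aryl group to a phenylethyl group. In an ADME assay on the whole organism with Oryza sativa as the target, tested at 1 uM (a higher number here means a weaker effect of the compound at the concentration tested, a lower number a stronger effect), compound 1 gives 100%, and compound 2 gives 100%, level with compound 1 within the scatter. Compound 3 `C[C@H](NC(=O)Nc1cccc(Br)c1)c1ccccc1` is the mirror image of compound 2: the two compounds have the same atoms and bonds and differ only in configuration as drawn: 1 of 1 stereo elements differ; a stereocentre at a saturated chain carbon is drawn R in compound 2 and S in compound 3. Within the data shown here, no measured pair shows the effect of inverting this centre, so compound 3 is expected to show no step beyond the scatter, no change at the digits printed from compound 2 to compound 3 (within the scatter). In this assay compound 3 is estimated at 100%, with a range from 85% to 100%.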

Compound 3, a percentage reported as activity, at one concentration (the size of the read-out at that concentration, not a potency): 100%
Compound 3: the middle estimate sits on the measured number at the digits printed; the measured number falls inside the stated range.
By their numbers in this assay, from the lowest: compounds 1, 2 and 3 (each within the scatter of the next).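

In this assay, among these compounds, inverting the stereocentre at the saturated chain carbon gives no change at the digits printed from compound 2 to compound 3 (within the scatter), the first direct reading of this centre, and nothing else enters this comparison: the fact that compounds 2 and 3 differ only in the configuration as drawn. Bromo in place of methyl on an aromatic carbon, read with this configuration, gives no change at the digits printed from compound 1 to compound 3 (within the scatter). Neither change therefore moves the read-out in this series.

Going by these compounds, since all the compounds shown sit at one level, it stays open whether this centre matters in a compound that departs from that level. On these data alone, it also stays open whether an amine or a carboxylic acid in place of the bromo would shift the read-out in this assay.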